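Cytotoxicity notes: chlorophenyl to thiazolyl exchange

The compounds below may be only part of what the source reports. "The series", "measured", "known", "first", "only" and "open" are said of these compounds alone.

compound 1 `COc1nc(-c2cccc(Cl)c2)ccc1[C@@H](c1ccccc1)[C@@](O)(CCN(C)C)c1cccc2ccccc12` — "nd" (no result reported)
compound 2 `COc1nc(-c2ccccc2Cl)ccc1[C@@H](c1ccccc1)[C@@](O)(CCN(C)C)c1cccc2ccccc12` — > 64 ug/mL
compound 3 `COc1nc(-c2ccc(Cl)cc2)ccc1[C@@H](c1ccccc1)[C@@](O)(CCN(C)C)c1cccc2ccccc12` — > 64 ug/mL

In a toxicity assay on HeLa cells (Homo sapiens) for cytotoxicity (a higher number here means that more compound is tolerated, a lower number that less compound is tolerated), compound 1 has no reported result, shown as "nd" (no result reported). For compound 2 only a limit of this assay is reached, > 64 ug/mL. For compound 3 the outcome is likewise a limit, > 64 ug/mL. The step that the two limits leave unreadable from compound 2 to compound 3 is therefore not readable in size because of the limit of > 64 ug/mL in this assay, at which 2 of the 3 values shown sit. Going by the values given here, compound 3 thus stands at a limit, with one further limit and one entry without a number beside it; no compound of the series has a single numerical value in this assay.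

Compound 4 `COc1nc(-c2cnsc2)ccc1[C@@H](c1ccccc1)[C@@](O)(CCN(C)C)c1cccc2ccccc12` is not yet measured. It differs from compound 3 by 1,2-thiazol-4-yl in place of 4-chlorophenyl on an aromatic carbon. Among the compounds with values here, no measured step of readable size bears on this change; the only step between measured compounds runs between two limits. The expectation for compound 4 rests on both measured values sitting at the limit, so no shift beyond the scatter is expected, and the step of a number no higher from compound 3 to compound 4 (the limit leaves the size open) is estimated as flat. Compound 4 is expected to give 64 ug/mL in this assay, within a range from 30 ug/mL to 120 ug/mL, most likely again reported only as a limit.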

Compound 4, half-maximal cytotoxic concentration: 28.8 ug/mL
Estimate against measurement, compound 4: 2.2-fold (0.35 log units) above; measured number outside the range, below it.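

In this assay, going by these compounds alone, the first single number of the series shows that this position, next to the ring nitrogen, does affect the tolerated concentration: the exchange of 4-chlorophenyl for 1,2-thiazol-4-yl gives an at least 2.2-fold lower number from compound 3 to compound 4 (0.34 log units; beyond the scatter). The exchange of 2-chlorophenyl for the same ring gives an at least 2.2-fold lower number from compound 2 to compound 4 (0.34 log units; beyond the scatter), so the two chlorophenyl compounds with a reported result point the same way, while compound 1 has no result to add. Both steps give only a minimum size, and the step between the two chlorophenyl compounds cannot be read, because those compounds sit at the limit of the assay: the limit of > 64 ug/mL in this assay, at which 2 of the 4 values shown sit.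

The exchange changes ring size, hetero atoms and hydrogen-bond acceptors together, so the compounds shown do not separate which of these differences goes with the lower number. Still open, going by these compounds, is whether an unsubstituted phenyl or a pyridinyl ring at this position would stay at the limit of the assay or give a number near that of compound 4, and whether other five-membered rings, such as a thiophene, would behave like 1,2-thiazol-4-yl.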